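A few compounds are considered here, and "the series" means these few. Any claim that something is new, unique, unknown or untested is made for them only; others in the source may bear on it.

In a functional assay on V79 cells (Cricetulus griseus) for cytotoxicity, read by colony formation (a higher number here means a weaker inhibitor, a lower number a stronger inhibitor), compound 3 `COc1c(N2CCNCC2)c(F)cc2c(=O)c(C(=O)O)cn(C3CC3)c12` gives 82 ug/mL and lies within the scatter of compound 2 `CC1(CN)CCN(c2c(F)cc3c(=O)c(C(=O)O)cn(C4CC4)c3c2C(F)(F)F)C1` at 110 ug/mL on this read-out. Compound 1 `O=C(O)c1cn(C2CC2)c2c(C(F)(F)F)c(N3CCCC3)c(F)cc2c1=O` gives 280 ug/mL in the same test, which lies clearly beyond the scatter of the other two.

Compound 4 `O=C(O)c1cn(C2CC2)c2c(C(F)(F)F)c(N3CCNCC3)c(F)cc2c1=O` carries trifluoromethyl in place of methoxy on an aromatic carbon and keeps the piperazin-1-yl group of compound 3.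

Going by the values given here, no measured step covers this exchange. The only one available, a 2.5-fold lower number from compound 1 to compound 2 (0.41 log units; beyond the scatter), is modest and concerns the amine on an aromatic carbon, so it bears only indirectly by showing how far trifluoromethyl compounds move with that group. Compounds 1 and 2 both carry trifluoromethyl, and neither gives a reason to expect a large shift.

The expected change in this assay is small, toward a higher number and probably within the scatter, estimated as a 1.6-fold higher number from compound 3 to compound 4 (0.20 log units; within the scatter) in all. For compound 4 the estimated value is 130 ug/mL with an expected range from 55 ug/mL to 300 ug/mL in this test.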

Compound 4, half-maximal inhibitory concentration: 1650 ug/mL
Compound 4: middle estimate off by 13-fold (1.10 log units), on the low side, outside the stated range (above it).
By their numbers in this assay, from the lowest: compounds 3 and 2 (each within the scatter of the next); then compound 1; then compound 4.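

At this aromatic carbon, ortho to a fused ring and ortho to a piperazin-1-yl group, the exchange of methoxy for trifluoromethyl is far from silent in this assay, with a 20-fold higher number from compound 3 to compound 4 (1.30 log units; beyond the scatter). With trifluoromethyl held in place, the amine also carries weight: piperazin-1-yl gives a 15-fold higher number from compound 2 to compound 4 (1.18 log units; beyond the scatter) against 3-(aminomethyl)-3-methylpyrrolidin-1-yl and a 5.9-fold higher number from compound 1 to compound 4 (0.77 log units; beyond the scatter) against pyrrolidin-1-yl, so a change at this neighbouring carbon can move the number well beyond what the first measured step showed. Nothing available accounts for either shift.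

Going by these compounds, whether the trifluoromethyl penalty holds with pyrrolidin-1-yl or 3-(aminomethyl)-3-methylpyrrolidin-1-yl in place of piperazin-1-yl remains open. So does the standing of a chloro, methyl or ethoxy group at this aromatic carbon relative to methoxy and trifluoromethyl.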